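A Methylsulfonyl Group Added to Compound 1

The source may hold more compounds than are shown below. What is called first, only, known or untested is meant among the compounds shown, and "the series" means these compounds.

Of the compounds shown here, three that share one core have been tested in a functional assay on the whole organism (Abdomen, strain Swiss) for inhibition, with Mus musculus as the target, with a stated time of 1 h, at a dose of 100 umol/kg by the oral route; a higher number here means more inhibition at the dose given (going by the name of the read-out), a lower number less inhibition. Compound 1 `c1ccc(Nc2c(-c3ccccc3)nc3ccccn23)cc1` gives 10.8%. Compound 2 `c1ccc(Nc2c(-c3ccncc3)nc3ccccn23)cc1` gives 13%, and compound 3 `c1ccc(Nc2c(-c3ccccn3)nc3ccccn23)cc1` gives -3%. Of these three numbers compound 1 stands second highest, though its gap to compound 2 is within the scatter: a number 2.2 percentage points higher from compound 1 to compound 2 (within the scatter). Its gap to compound 3 is larger: a number 13.8 percentage points lower from compound 1 to compound 3 (beyond the scatter). The remaining step is also modest: a number 16 percentage points lower from compound 2 to compound 3 (beyond the scatter).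

Compound 4 `CS(=O)(=O)c1ccc(-c2nc3ccccn3c2Nc2ccccc2)cc1` differs from compound 1 in one place: methylsulfonyl in place of hydrogen on an aromatic carbon. Among the measured compounds shown here, none of the measured steps adds a group to the phenyl; each exchanges the phenyl itself for a pyridinyl group. So no measured step bears directly on this change. What the measured steps do show is that changes at this part of the core move this assay only modestly, and that all three numbers sit low. Without a direct comparison, the expectation for compound 4 is a number close to that of compound 1, with a wide range. The expected step is a number 1.2 percentage points higher from compound 1 to compound 4 (within the scatter), none beyond the scatter. Compound 4 is estimated at 12%, between 0% and 28%.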

Compound 4, a percentage reported as inhibition, in the whole organism at one dose (the size of the read-out at that dose, not a potency): 7.4%
Compound 4: the middle estimate sits 4.6 percentage points above what was measured, within the range that was stated.
By their numbers in this assay, from the lowest: compound 3; then compounds 4, 1 and 2 (each within the scatter of the next).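

Among the compounds shown here, the earlier steps each exchanged the whole phenyl for a pyridinyl group, so compound 4 is the first case here in which a group is added to that phenyl, and in this assay the step is a number 3.4 percentage points lower from compound 1 to compound 4 (within the scatter) and does not stand out from the scatter. A methylsulfonyl group, with its 4 heavy atoms and 2 hydrogen-bond acceptors, can therefore sit on this ring, para to a large group, without a detectable shift in the read-out, and the number stays in the same low range as those of compound 1 and compound 2. No measurement is available that would explain this outcome.

This single example does not show whether the position is insensitive to substitution in general, since an amine, a carboxylic acid or a simple methoxy group at the same place could behave differently. It also leaves open whether methylsulfonyl would give a similar result on the other phenyl ring, or whether any change to the shared core can raise the inhibition well above these low numbers.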